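Swapping the Sulfonyl for Phenyl on the Hydrazone Nitrogen

The source may hold more compounds than are shown below. What is called first, only, known or untested is meant among the compounds shown, and "the series" means these compounds.

Measured in a functional assay on MCF7 cells (Homo sapiens) for cytotoxicity, read by sulforhodamine B assay, with a stated time of 24 h; a lower number here means a stronger inhibitor, a higher number a weaker inhibitor:
compound 1 `N#CCC(=O)N/N=C1\C(=O)Nc2ccc(S(=O)(=O)N3CCOCC3)cc21` gives 27700 nM
compound 2 `CC(=O)c1cccc(/N=C2\C(=O)Nc3ccc(S(=O)(=O)N4CCOCC4)cc32)c1` gives 39200 nM
compound 3 `Cc1ccc(S(=O)(=O)N/N=C2\C(=O)Nc3ccc(S(=O)(=O)N4CCOCC4)cc32)cc1` gives 38400 nM

The three numbers sit close together. Compound 3 lies within the scatter of both others, with compound 2 nearest and compound 1 furthest; none of these gaps exceeds the scatter. Compound 4 `O=C1Nc2ccc(S(=O)(=O)N3CCOCC3)cc2/C1=N/Nc1ccccc1` differs from compound 3 in one place: phenyl in place of (4-methylphenyl)sulfonyl on an amine nitrogen. Two measured steps alter the same position and therefore bear on it. a 1.4-fold higher number from compound 1 to compound 2 (0.15 log units; within the scatter). a 1.4-fold higher number from compound 1 to compound 3 (0.14 log units; within the scatter). Because a 1.4-fold higher number from compound 1 to compound 2 (0.15 log units; within the scatter) and a 1.4-fold higher number from compound 1 to compound 3 (0.14 log units; within the scatter) both stayed within the scatter, the step to compound 4 is expected to be no larger than the scatter: a 1.1-fold lower number from compound 3 to compound 4 (0.04 log units; within the scatter). Compound 4 is accordingly estimated at 35000 nM in this assay, with a range from 15000 nM to 80000 nM.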

Compound 4, half-maximal inhibitory concentration: 30300 nM
The estimate for compound 4 lay 1.2-fold (0.06 log units) above the measured number; the range from low to high includes it.
By their numbers in this assay, from the lowest: compounds 1, 4, 3 and 2 (each within the scatter of the next).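

In this assay, phenyl on the amine nitrogen gives a number within the scatter of the (4-methylphenyl)sulfonyl group (a 1.3-fold lower number from compound 3 to compound 4 (0.10 log units; within the scatter)). The same holds against the other two compounds (a 1.3-fold lower number from compound 2 to compound 4 (0.11 log units; within the scatter); a 1.1-fold higher number from compound 1 to compound 4 (0.04 log units; within the scatter)), so a plain phenyl joins the three earlier groups without separating from any of them. No evidence is available to explain why these numbers stay so close. From the compounds shown here alone, whether a carboxylic acid or a basic amine on a longer chain at this nitrogen would give a step beyond the scatter remains open.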